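The source may report more compounds than this note shows. Statements on the series, on what has been measured and on what is new or still open speak of the compounds shown alone.

In a functional assay on MCF7 cells (Homo sapiens), read by MTT assay, with a stated time of 48 h (a lower number here means a stronger inhibitor, a higher number a weaker inhibitor), three compounds sharing one core have been measured, and they differ in the group on a carbonyl carbon. Compound 1 `CCN(CC)CCNC(=O)c1ccc(C(CC)(CC)c2ccc(OCC(O)C(C)(C)C)c(C)c2)n1CC` gives 690 nM. Compound 3 `CCn1c(C(=O)N(CCC#N)CCC#N)ccc1C(CC)(CC)c1ccc(OCC(O)C(C)(C)C)c(C)c1` gives 480 nM. Compound 2 `C#CCNC(=O)c1ccc(C(CC)(CC)c2ccc(OCC(O)C(C)(C)C)c(C)c2)n1CC` gives > 50000 nM, which is a limit of the assay and not a number.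

Compound 3 therefore stands together with compound 1 and well apart from that limit. The data show a 1.4-fold lower number from compound 1 to compound 3 (0.16 log units; within the scatter), a step within the scatter, but also an at least 72-fold higher number from compound 1 to compound 2 (1.86 log units; beyond the scatter), a large step.

Compound 4 `CCn1c(C(=O)OCc2ccc(F)cc2)ccc1C(CC)(CC)c1ccc(OCC(O)C(C)(C)C)c(C)c1` carries a new group on the same carbonyl carbon: a group of 9 heavy atoms (7 carbon, 1 oxygen, 1 fluorine; one six-membered aromatic ring of carbon only) in place of a group of 9 heavy atoms (6 carbon, 3 nitrogen; no ring), on a carbonyl carbon. Among the compounds with values here, no measured step makes this exchange, so the nearest guides are the other changes at this carbon. They range from the small step above to an at least 100-fold lower number from compound 2 to compound 3 (2.01 log units; beyond the scatter), so a change here can matter little or a great deal. Neither of the two groups that hold the number low resembles (4-fluorobenzyl)oxy, so some weakening in this assay is expected, though its size is uncertain. The estimated step is a 5.2-fold higher number from compound 3 to compound 4 (0.72 log units; beyond the scatter), a rise beyond the scatter. For compound 4 the estimated value is 2500 nM, with an expected range from 300 nM to 30000 nM.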

Compound 4, half-maximal inhibitory concentration: > 50000 nM
Compound 4: only a limit was reported; the forecaster's own chance of this, stated with the estimate: 20%; at least 20-fold (1.30 log units) between middle value and limit.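

In this assay the (4-fluorobenzyl)oxy group on the carbonyl carbon brings an at least 100-fold higher number from compound 3 to compound 4 (2.01 log units; beyond the scatter), and the comparison with the other measured compound brings an at least 72-fold higher number from compound 1 to compound 4 (1.86 log units; beyond the scatter). The reading for compound 4 is a limit and not a number, and it is the same limit as for compound 2: the limit of > 50000 nM in this assay, at which 2 of the 4 values shown sit. Within the data shown here, earlier, the only large step at this carbon came from propargylamino, a small group attached through nitrogen, whereas this result shows that a group attached through oxygen and carrying an aromatic ring can also give a large step, even though the group that leaves has the same heavy-atom count and also has no hydrogen-bond donors.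

On these data alone, the step between compound 2 and compound 4 cannot be read, as both readings are limits, so the order of these two stays unknown. The compounds shown also leave open whether the linking oxygen or the aromatic ring goes with the large step, a question that a (4-fluorobenzyl)amino group, with the same ring attached through nitrogen, or a simple ethoxy group, with oxygen and no ring, could help to separate.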